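Swapping the amide-linked aryl group: from anilide to chloroanilide

The source may report more compounds than this note shows. Statements on the series, on what has been measured and on what is new or still open speak of the compounds shown alone.

Measured so far:
compound 1 `O=C(CSc1nc(Nc2ccccc2)c2ccccc2n1)Nc1cccc(Br)c1` — 17500 nM
compound 2 `C=CC(=O)Nc1cccc(NC(=O)CSc2nc(Nc3ccccc3)c3ccccc3n2)c1` — 10200 nM

In a functional assay on MDA-MB-231 cells (Homo sapiens) for inhibition, read by MTT assay, with a stated time of 72 h (on this read-out lower numbers stand for stronger inhibition and higher numbers for weaker inhibition), compound 2 shows the lowest of the two numbers; compound 1 sits nearest, and the step of a 1.7-fold lower number from compound 1 to compound 2 (0.23 log units; within the scatter) lies within the scatter. Compound 3 `O=C(CSc1nc(Nc2ccccc2)c2ccccc2n1)Nc1ccc(Cl)cc1` differs from compound 2 by 4-chlorophenyl in place of 3-((vinylcarbonyl)amino)phenyl on an amide-type nitrogen. Among the measured compounds shown here, the only measured step touching this amide-linked aryl group, a 1.7-fold lower number from compound 1 to compound 2 (0.23 log units; within the scatter), was within the scatter, so no change beyond the scatter is expected for compound 3 in this assay. Compound 3 is estimated at 14000 nM (range 5000 nM to 45000 nM), a step of a 1.4-fold higher number from compound 2 to compound 3 (0.14 log units; within the scatter) expected from compound 2.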

Compound 3, half-maximal inhibitory concentration: 17200 nM
The estimate for compound 3 lay 1.2-fold (0.09 log units) below the measured number; low and high end bracket the measured number.
By their numbers in this assay, from the lowest: compounds 2, 3 and 1 (each within the scatter of the next).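

Read in this assay the step of a 1.7-fold higher number from compound 2 to compound 3 (0.23 log units; within the scatter) puts 4-chlorophenyl in place of 3-((vinylcarbonyl)amino)phenyl, and the step of a 1.0-fold lower number from compound 1 to compound 3 (0.01 log units; within the scatter) puts it in place of 3-bromophenyl on the same amide-type nitrogen. Both steps lie within the scatter, so three different aryl groups at this position now give readings that cannot be told apart. No supporting measurement speaks to the reason for this. Going by these compounds, whether a carboxylic acid or an amine on this ring would move the number beyond the scatter remains open.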